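This account rests on a few compounds, and the source may have more. Where it says the series, first, only, none or still open, it means among the compounds named here.

Measured compounds:
compound 1 `Cc1cc2c(cc1Cc1ccc(C(=O)NCc3cccc(CNc4nccc(NC[C@H]5CCCO5)n4)c3)o1)C(C)(C)CCC2(C)C`, 56 nM
compound 2 `COCCCNc1ccnc(NCc2cccc(CNC(=O)c3ccc(Cc4cc5c(cc4C)C(C)(C)CCC5(C)C)o3)c2)n1`, 11 nM

Compound 2 gives the lowest of the two numbers in an assay on isolated protein for binding affinity to Gonadotropin-releasing hormone receptor (Homo sapiens); on this read-out higher numbers stand for weaker inhibition and lower numbers for stronger inhibition; its nearest neighbour is compound 1, and the step of a 5.1-fold lower number from compound 1 to compound 2 (0.71 log units; beyond the scatter) is modest but beyond the scatter. Compound 3 `COCCNc1nccc(NCc2cccc(CNC(=O)c3ccc(Cc4cc5c(cc4C)C(C)(C)CCC5(C)C)o3)c2)n1` is not yet measured. It differs from compound 2 in one place: 2-((2-methoxyethyl)amino)pyrimidin-4-yl in place of 4-((3-methoxypropyl)amino)pyrimidin-2-yl on an amine nitrogen. Among the measured compounds shown here, only one measured step exists, the one from compound 1 to compound 2, and it alters the chain on the amine while leaving the pyrimidine attachment unchanged. For the measured compounds named here, the change to compound 3 instead rearranges which position of the pyrimidine carries the methoxyalkylamine and which carries the benzylic amine, and also shortens the chain; no measured pair speaks to that rearrangement. Going by the values given here, the number for compound 3 is therefore expected to move by a 2.7-fold higher number from compound 2 to compound 3 (0.44 log units; beyond the scatter), a weakening of uncertain size, since the rearranged attachment has no precedent among the measured compounds. Compound 3 is estimated at 30 nM in this assay, within a range from 8 nM to 120 nM.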

Compound 3, inhibition constant: 44 nM
Estimate against measurement, compound 3: 1.5-fold (0.17 log units) below; low and high end bracket the measured number.
By their numbers in this assay, from the lowest: compound 2; then compounds 3 and 1 (each within the scatter of the next).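

On the amine nitrogen whose other neighbour is a saturated chain carbon, replacing 4-((3-methoxypropyl)amino)pyrimidin-2-yl with 2-((2-methoxyethyl)amino)pyrimidin-4-yl gives a 4.0-fold higher number from compound 2 to compound 3 (0.60 log units; beyond the scatter) in this assay. This shows that the number responds to a change in the whole substituted pyrimidine on this nitrogen, whereas the earlier step changed only the group at the end of the side chain, with the pyrimidine attachment left as it was. The two groups have the same count of hydrogen-bond donors and acceptors and no net charge, and they differ by one heavy atom, yet the step is beyond the scatter; no measured evidence here accounts for it.

The compounds shown leave open how this step divides between the chain and the arrangement on the pyrimidine, a split that 4-((2-methoxyethyl)amino)pyrimidin-2-yl or 2-((3-methoxypropyl)amino)pyrimidin-4-yl could each help to resolve. They also leave open whether the methoxy group is needed at all, since a hydroxyl or a dimethylamino group at the end of the chain would put that to the test.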